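Adding One Methyl to Compound 2

The source may hold more compounds than are shown below. What is called first, only, known or untested is meant among the compounds shown, and "the series" means these compounds.

Compound 1 `Cc1c(C)c2ccc(OCC(=O)NN)cc2oc1=O` gives 9.14 nM here
Compound 2 `Cc1cc(=O)oc2cc(OCC(=O)NNC(=S)Nc3ccc(Cl)cc3)ccc12` gives 41.4 nM here

In a functional assay on the whole organism (strain Wistar) for inhibition, with Rattus norvegicus as the target, with a stated time of 4 h (on this read-out lower numbers stand for an effect already at smaller amounts and higher numbers for an effect only at larger amounts of compound), compound 2 has the higher of the two numbers, and compound 1 lies lower by a gap beyond the usual scatter. Compound 2 therefore needs the larger amount to reach the same effect.

Compound 3 `Cc1c(C)c2ccc(OCC(=O)NNC(=S)Nc3ccc(Cl)cc3)cc2oc1=O` is the next to be measured. It differs from compound 2 by methyl in place of hydrogen on an aromatic carbon. This is a small edit, and the rest of the molecule stays the same.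

Compound 1 at 9.14 nM also carries this methyl, but its chain differs from that of compound 2 as well. The gap between the two therefore gives no clean measure of what the methyl alone does. With no direct evidence for a direction, the expected 1.2-fold lower number from compound 2 to compound 3 (0.07 log units; within the scatter) is small and estimated to stay within the scatter. For compound 3 the expected value is 35 nM within an estimated range from 14 nM to 85 nM on repeated measurement.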

Compound 3, concentration for half-maximal effect: 196 nM
Compound 3: middle estimate off by 5.6-fold (0.75 log units), on the low side; the measured number lies above the stated range.
By their numbers in this assay, from the lowest: compound 1; then compound 2; then compound 3.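

In this assay, going by these compounds alone, swapping one hydrogen for methyl gives a 4.7-fold higher number from compound 2 to compound 3 (0.68 log units; beyond the scatter), the first reading of this change with the rest of the molecule held constant. A larger amount of compound is therefore needed for the same effect once the methyl is present, so this position, on an aromatic carbon of the six-membered aromatic ring with 1 oxygen and ortho to a methyl group, is sensitive: a single added carbon is enough to move the number beyond the usual scatter. Nothing measured here explains why the number moves in this direction.

Compound 1 also carries this methyl and gives 9.14 nM, but with a different chain and no partner lacking the methyl among the compounds shown, so it remains open whether the methyl raises the number with that chain as well. Also open, from the compounds shown here alone, is whether the rise is specific to methyl or would be matched, reversed or exceeded by another group at the same position, such as ethyl, chlorine or an amine.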